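This account rests on a few compounds, and the source may have more. Where it says the series, first, only, none or still open, it means among the compounds named here.

Working notes on the series

The parent, compound 1 `O=c1c(SC(=S)N2CCCCC2)coc2ccccc12`, gives 7800 nM in a functional assay on LM7 cells (Homo sapiens) for antiproliferative activity, read by MTT assay, with a stated time of 72 h; a lower number here means a stronger inhibitor, a higher number a weaker inhibitor. Compound 2 `O=c1c(SC(=S)N2CCCCC2)coc2ccc(Cl)cc12` carries chloro in place of hydrogen on an aromatic carbon and in this assay compound 2 reaches only the assay limit of > 25000 nM, a limit rather than a number. That change produced an at least 3.2-fold higher number from compound 1 to compound 2 (0.50 log units; beyond the scatter). Among the three values so far, (the limit of > 25000 nM in this assay, at which 1 of the 3 values shown sits).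

Compound 3 `CC(C)N(C(=S)SCc1coc2ccccc2c1=O)C(C)C` is a second core; how it differs from the core of compound 1 is not broken down here. In this assay compound 3 gives 21900 nM, the highest of the two numbers obtained, and a higher number than compound 1.

Compound 4 `CC(C)N(C(=S)SCc1coc2cc(Cl)ccc2c1=O)C(C)C` is not yet measured. It carries the same change as compound 2 does, namely (chloro in place of hydrogen on an aromatic carbon). The place of the chloro is the same in both pairs.

Compound 4 is expected to follow compound 2 because an at least 3.2-fold higher number from compound 1 to compound 2 (0.50 log units; beyond the scatter) was at least modest and compound 3 already starts from a high number. The estimated step is a 2.7-fold higher number from compound 3 to compound 4 (0.44 log units; beyond the scatter). The estimate for compound 4 in this assay is 60000 nM, between 22000 nM and 160000 nM, with a real chance that only a limit is reported.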

Compound 4, half-maximal inhibitory concentration: > 25000 nM
Compound 4: no number, only a limit; the forecaster's own chance of this, stated with the estimate: 75%; the middle value lies beyond the limit too.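

In this assay compound 4 gives only a limit, > 25000 nM, and not a number. Chloro in place of hydrogen on an aromatic carbon thus gives an at least 1.1-fold higher number from compound 3 to compound 4 (0.05 log units; that floor lies within the scatter), so a rise beyond the scatter on this core is neither shown nor excluded. Carrying the change from one core to the other is therefore not shown to keep its size, and not shown to alter it: the same change on two cores in this assay, an at least 3.2-fold higher number (0.50 log units; beyond the scatter) from compound 1 to compound 2 and an at least 1.1-fold higher number (0.05 log units; that floor lies within the scatter) from compound 3 to compound 4; the limit leaves it open whether they differ

The compounds shown leave open how far the two chloro compounds, compound 2 and compound 4, actually lie past the limit, so the comparison between the cores stays bounded by the assay itself: the limit of > 25000 nM in this assay, at which 2 of the 4 values shown sit. They also leave open whether an amine, a carboxylic acid or a methoxy group in place of the chloro, on either core, would give a value that can be read as a number in this assay.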